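This account rests on a few compounds, and the source may have more. Where it says the series, first, only, none or still open, it means among the compounds named here.

In a functional assay on HeLa S3 cells (Homo sapiens) for antiproliferative activity, read by XTT assay, with a stated time of 72 h (on this read-out lower numbers stand for stronger inhibition and higher numbers for weaker inhibition), compound 1 `C#Cc1cn([C@@H]2O[C@H](CO)[C@@H](O)[C@H]2O)c2ncnc(SC)c12` gives 110 nM. Compound 2 `CN(C)c1ncnc2c1c(-c1cc3ccccc3o1)cn2[C@@H]1O[C@H](CO)[C@@H](O)[C@H]1O` gives only a limit of the assay, > 20000 nM, so it stands at the weak end of the numbers shown. Compound 3 `C#Cc1cn([C@@H]2O[C@H](CO)[C@@H](O)[C@H]2O)c2ncnc(N(C)C)c12` has ethynyl in place of 1-benzofuran-2-yl on an aromatic carbon. A large gain in this assay is expected, toward lower numbers, because ethynyl also stands in compound 1 at 110 nM. The expected change is an at least 20-fold lower number from compound 2 to compound 3 (1.30 log units; beyond the scatter), which is an estimate only. For compound 3 the estimated value is 1000 nM, with an expected range from 150 nM to 8000 nM.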

Compound 3, half-maximal inhibitory concentration: 810 nM
The estimate for compound 3 lay 1.2-fold (0.09 log units) above the measured number, within the range that was stated.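

In this assay, ethynyl in place of 1-benzofuran-2-yl on this aromatic carbon gives an at least 24-fold lower number from compound 2 to compound 3 (1.39 log units; beyond the scatter), so with dimethylamino held fixed, the group at this position alone moves the number by a large margin. As far as these compounds go, the true size of that step remains unknown, as compound 2 stands at a limit of the assay: the limit of > 20000 nM in this assay, at which 1 of the 3 values shown sits. With ethynyl held fixed, dimethylamino in place of methylsulfanyl gives a 7.4-fold higher number from compound 1 to compound 3 (0.87 log units; beyond the scatter), so the change at this other aromatic carbon is modest by comparison. Open, from the compounds shown here alone, is how a methyl or phenyl group at the ethynyl position would compare, and whether 1-benzofuran-2-yl would fare better alongside methylsulfanyl.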